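Anilide substituent survey on the shared core in paw edema

A few compounds are considered here, and "the series" means these few. Any claim that something is new, unique, unknown or untested is made for them only; others in the source may bear on it.

Measured so far:
compound 1 `O=C(Nc1ccccc1)c1c(O)c2cccnc2n(-c2ccccc2)c1=O` — 4.6%
compound 2 `O=C(Nc1ccc(Cl)cc1)c1c(O)c2cccnc2n(-c2ccccc2)c1=O` — 11.6%
compound 3 `O=C(Nc1ccc([N+](=O)[O-])cc1)c1c(O)c2cccnc2n(-c2ccccc2)c1=O` — -7.6%

In a functional assay on the whole organism for inhibition, with Rattus norvegicus as the target, read by paw edema, at a dose of 100 mg/kg by the oral route (on this read-out lower numbers stand for less inhibition and higher numbers for more inhibition at the one dose given (going by the name of the read-out)), compound 3 gives -7.6%, the lowest of the three values. The steps leading to it are a number 12.2 percentage points lower from compound 1 to compound 3 (beyond the scatter) and a number 19.2 percentage points lower from compound 2 to compound 3 (beyond the scatter), both beyond the scatter, while a number 7 percentage points higher from compound 1 to compound 2 (within the scatter) is within it.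

Compound 4 `COc1ccccc1NC(=O)c1c(O)c2cccnc2n(-c2ccccc2)c1=O` differs from compound 3 in one place: 2-methoxyphenyl in place of 4-nitrophenyl on an amide-type nitrogen. Going by the values given here, both steps that introduce nitro on the aromatic carbon lowered the read-out, so taking it away is expected to raise it; the methoxy group itself has no precedent here. The expected step is a number 12.6 percentage points higher from compound 3 to compound 4 (beyond the scatter), bringing compound 4 near the level of compound 1. Compound 4 is therefore estimated at 5%, with a range from -8% to 18%.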

Compound 4, a percentage reported as inhibition, in the whole organism at one dose (the size of the read-out at that dose, not a potency): 8.1%
Beside the measured number, compound 4's estimate is 3.1 percentage points below it; the range from low to high includes it.
By their numbers in this assay, from the lowest: compound 3; then compounds 1, 4 and 2 (each within the scatter of the next).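

In this assay, 2-methoxyphenyl in place of 4-nitrophenyl on the amide-type nitrogen gives a number 15.7 percentage points higher from compound 3 to compound 4 (beyond the scatter), so the low number of compound 3 is not shared by every substituted anilide. Methoxy in place of hydrogen gives a number 3.5 percentage points higher from compound 1 to compound 4 (within the scatter) and 2-methoxyphenyl in place of 4-chlorophenyl gives a number 3.5 percentage points lower from compound 2 to compound 4 (within the scatter), which puts methoxy, like chloro, within the scatter of the unsubstituted anilide. Nothing at hand bears on the reason for these steps. Open, from the compounds shown here alone, are whether an amine or a carboxylic acid on this ring would lift the read-out beyond the scatter of compound 1, and whether 4-methoxyphenyl would read like 2-methoxyphenyl.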